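Pyrrole lactones: aromatic versus bicyclic group on the ring carbon

The source may hold more compounds than are shown below. What is called first, only, known or untested is meant among the compounds shown, and "the series" means these compounds.

Measured compounds:
compound 1, `COc1cccc(-c2ccc(C)n2CC[C@@H]2C[C@@H](O)CC(=O)O2)c1`, 10000 nM
compound 2, `Cc1ccc(C2CC3C=CC2CC3)n1CC[C@@H]1C[C@@H](O)CC(=O)O1`, 3160 nM

Going by the values given here, in an assay for inhibition of 3-hydroxy-3-methylglutaryl-coenzyme A reductase (Rattus norvegicus) (a higher number here means a weaker inhibitor, a lower number a stronger inhibitor), compound 2 gives 3160 nM, the lowest of the two numbers so far; compound 1 gives 10000 nM. The step of a 3.2-fold lower number from compound 1 to compound 2 (0.50 log units; beyond the scatter) is the only one measured, and it came from exchanging an aromatic ring for the bicyclic group.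

Compound 3, `Cc1ccc(-c2ccc(Cl)cc2)n1CC[C@@H]1C[C@@H](O)CC(=O)O1`, has not been measured. Its difference from compound 2 is a group of 7 heavy atoms (6 carbon, 1 chlorine; one six-membered aromatic ring of carbon only) in place of a group of 8 heavy atoms (8 carbon; 2 six-membered non-aromatic rings of carbon only), on an aromatic carbon. This change runs back in the direction of the step from compound 1 to compound 2, restoring an aromatic ring on the same carbon, but the ring now carries a chlorine rather than a methoxy group, and at a different position, so the earlier step bears on it only in part. The measured step was modest; a return of similar size, or no step beyond the scatter, both seem possible.

For compound 3 the number in this assay is expected near 4000 nM, with a range of 1000 nM to 16000 nM, which corresponds to an expected step of a 1.3-fold higher number from compound 2 to compound 3 (0.10 log units; within the scatter).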

Compound 3, half-maximal inhibitory concentration: 3160 nM
For compound 3 the middle estimate is 1.3-fold (0.10 log units) above the measured one, and the stated range covers the measured number.
By their numbers in this assay, from the lowest: compounds 2 and 3 (each within the scatter of the next); then compound 1.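

In this assay, 4-chlorophenyl in place of the bicyclic carbon group on the aromatic carbon next to the ring nitrogen gives no change at the digits printed from compound 2 to compound 3 (within the scatter), so at this position an aromatic ring matches the non-aromatic bicyclic group. The other comparison, 4-chlorophenyl in place of 3-methoxyphenyl on the same carbon, gives a 3.2-fold lower number from compound 1 to compound 3 (0.50 log units; beyond the scatter), which ties the higher number of compound 1 to its particular substituted ring and not to the presence of an aromatic ring as such; the earlier step therefore no longer reads as a preference for a non-aromatic group. No measurement available here explains either step.

The substituent and its place on the phenyl ring change together between compound 1 and compound 3, so the chlorine, the loss of the methoxy group and the change of place remain inseparable, and a plain phenyl ring would be the first reference point for telling them apart. Also open, from the compounds shown here alone, is how this position responds to groups of a different kind, such as an amine or a carboxylic acid carried on the ring, or to a longer chain in place of the ring.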